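Replacing the triazolyl sulfur link in a peptidomimetic

The source may report more compounds than this note shows. Statements on the series, on what has been measured and on what is new or still open speak of the compounds shown alone.

Compound 1 `CC(C)[C@H](NC(=O)COc1cccc2ccccc12)C(=O)N[C@@H](CC(=O)O)C(=O)CSc1nc(-c2ccccc2)cs1` — > 200000 nM in a functional assay on Jurkat cells (Homo sapiens) for inhibition; on this read-out lower numbers stand for stronger inhibition and higher numbers for weaker inhibition
Compound 2 `CC(C)[C@H](NC(=O)COc1cccc2ccccc12)C(=O)N[C@@H](CC(=O)O)C(=O)CSc1nncn1C` — > 200000 nM
Compound 3 `Cc1cc(OCC(=O)[C@H](CC(=O)O)NC(=O)[C@@H](NC(=O)COc2cccc3ccccc23)C(C)C)nc(C)n1` — > 200000 nM

The value of compound 2 in this assay is a limit of the assay, not a number. The same holds for compound 1, whose value is a limit. The value of compound 3 is a limit as well. the limit of > 200000 nM in this assay, at which 3 of the 3 values shown sit, describes where the measured set stands. Compound 4 `CC(C)[C@H](NC(=O)COc1cccc2ccccc12)C(=O)N[C@@H](CC(=O)O)C(=O)COc1nccc(C(F)(F)F)n1` differs from compound 2 as follows: (4-(trifluoromethyl)pyrimidin-2-yl)oxy in place of (4-methyl-4H-1,2,4-triazol-3-yl)sulfanyl on a saturated chain carbon bound to a carbonyl carbon. Going by the values given here, the steps that bear on this change are a step that the two limits leave unreadable from compound 2 to compound 3, a step that the two limits leave unreadable from compound 1 to compound 2 and a step that the two limits leave unreadable from compound 1 to compound 3; none of them has a readable size. With no readable step on the shared core, the expected step is a number no higher from compound 2 to compound 4 (the limit leaves the size open), and compound 4 is estimated at 200000 nM, within 50000 nM to 1000000 nM.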

Compound 4, half-maximal inhibitory concentration: > 200000 nM
Compound 4: only a limit was reported; the forecaster's own chance of this, stated with the estimate: 80%; the middle value sits exactly at the limit.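

In this assay, going by these compounds alone, compound 4 gives > 200000 nM, a limit and not a number, so no step from compound 1, compound 2 or compound 3 to compound 4 can be read. The compounds shown leave open how strongly any of them inhibits, as all stand at one point: the limit of > 200000 nM in this assay, at which 4 of the 4 values shown sit.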